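This account rests on a few compounds, and the source may have more. Where it says the series, first, only, none or still open, it means among the compounds named here.

Measured compounds: compound 1 `CCC(=O)N1N=C(C)CC1c1cc(Br)ccc1O` with 37800 nM in a functional assay on PC-3 cells (Homo sapiens) for cytotoxicity, read by MTT assay, with a stated time of 48 h; on this read-out higher numbers stand for weaker inhibition and lower numbers for stronger inhibition; compound 2 `CC1=NN(C(=O)COc2ccc(Cl)cc2)C(c2cc(Br)ccc2O)C1` with 49000 nM in this assay.

Within the data shown here, compound 1 holds the lower of the two numbers, and its only neighbour is compound 2: the step of a 1.3-fold higher number from compound 1 to compound 2 (0.11 log units; within the scatter) concerns a change on the chain bound to the carbonyl carbon, so the two numbers are not told apart by the assay.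

Compound 3 `CCC(=O)N1N=C(C)CC1c1cc(Br)cc(Br)c1O` carries the change (bromo in place of hydrogen on an aromatic carbon). Among the measured compounds shown here, no measured step touches this part of the structure; the single step available concerns the chain at the carbonyl carbon and not the aromatic ring bearing the hydroxy group. The two measured values themselves sit close together, which suggests that the series has so far moved little on this read-out.

For the measured compounds named here, with no step on the ring to lean on, the expectation for compound 3 is a number near that of compound 1, with the step of a 1.2-fold lower number from compound 1 to compound 3 (0.07 log units; within the scatter) estimated to stay inside the scatter. Compound 3 is therefore estimated at 32000 nM, with a range from 11000 nM to 95000 nM.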

Compound 3, half-maximal inhibitory concentration: 28600 nM
Estimate against measurement, compound 3: 1.1-fold (0.05 log units) above, within the range that was stated.
By their numbers in this assay, from the lowest: compounds 3, 1 and 2 (each within the scatter of the next).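

Bromo in place of hydrogen on an aromatic carbon, ortho to a hydroxy group and meta to a bromo group, gives the only step on this ring in this assay: a 1.3-fold lower number from compound 1 to compound 3 (0.12 log units; within the scatter). Among these compounds, the earlier step concerned only the chain at the carbonyl carbon, so this is the first reading of the position, and it shows that a bromo there can be carried without a difference that this assay can resolve from the hydrogen of compound 1. Nothing at hand offers an explanation for this result.

The compounds shown hold only hydrogen and bromo at this position, so it remains open whether an amine, a carboxylic acid or a methoxy group there would give a step beyond the scatter. On these data alone, it is also open whether bromo at this position would give the same result when combined with the 4-chlorophenoxy chain of compound 2, or whether the hydroxy group itself matters to the numbers in this assay.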